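The source may report more compounds than this note shows. Statements on the series, on what has been measured and on what is new or still open speak of the compounds shown alone.

In a functional assay on CCRF-CEM cells (Homo sapiens) for antiproliferative activity (on this read-out lower numbers stand for stronger inhibition and higher numbers for weaker inhibition), compound 1 (`COc1cc(C(=O)c2ccc3c(ccn3C)c2)cc(OC)c1OC`) gives 18 nM and compound 2 (`COc1cc(C(=O)c2ccc3ccn(C)c3c2)cc(OC)c1OC`) gives 30 nM and these two numbers lie within the usual scatter of each other. Going by the values given here, compound 1 therefore stands level with the only other measured compound, and both show inhibition at low concentrations. Compound 3 (`COc1cc(OC)cc(C(=O)c2ccc3c(ccn3C)c2)c1`) has not yet been measured. Its structure differs from that of compound 1 in one place, described as hydrogen in place of methoxy on an aromatic carbon and amounting to hydrogen in place of methoxy on an aromatic carbon, ortho to two methoxy groups and para to a large group. Among the compounds with values here, no measured pair here shows what such a change does, so any expectation for this assay rests on judgement and carries wide uncertainty. Starting from compound 1 at 18 nM a move toward a higher number, meaning weaker inhibition and lying beyond the scatter, is expected. The estimated step of a 6.7-fold higher number from compound 1 to compound 3 (0.82 log units; beyond the scatter) is expected to be moderate rather than a complete loss of activity. For compound 3 the estimated value is 120 nM with an expected range from 30 nM to 600 nM for now.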

Compound 3, half-maximal inhibitory concentration: 1690 nM
Compound 3: middle estimate off by 14-fold (1.15 log units), on the low side; the measured number lies above the stated range.
By their numbers in this assay, from the lowest: compounds 1 and 2 (each within the scatter of the next); then compound 3.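

In this assay, hydrogen in place of methoxy on this aromatic carbon, ortho to two methoxy groups and para to a large group, gives a 94-fold higher number from compound 1 to compound 3 (1.97 log units; beyond the scatter) and so counts as a large step, well beyond the scatter. The earlier compounds shown here showed only that inhibition at low concentrations was possible with this methoxy group present, whereas this pair shows that the read-out depends strongly on this one place: the change removes only 2 heavy atoms and 1 hydrogen-bond acceptor, yet inhibition becomes much weaker. Nothing available here accounts for the size of this step.

The compounds shown leave open whether the methoxy group itself is required or whether another small group on the same carbon, such as a hydroxy group, a fluorine atom or an ethoxy group, would hold the activity of compound 1. They also leave open whether the same replacement would cost as much on the core of compound 2, so the size of this step is established for the core of compound 1 alone.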